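Methoxy for Hydroxymethyl, Carried onto a Second Core

This account rests on a few compounds, and the source may have more. Where it says the series, first, only, none or still open, it means among the compounds named here.

Compound 1 `CCCn1c(=O)n(CCCO)c(=O)c2[nH]cnc21` and compound 2 `CCCn1c(=O)n(CCOC)c(=O)c2[nH]cnc21` share one core, while compound 3 `CCCn1c(=O)n(C)c(=O)c2c1ncn2CCCO` and compound 4 `CCCn1c(=O)n(C)c(=O)c2c1ncn2CCOC` share another; the difference between the two cores is not broken down here. In a functional assay (trachea) with Cavia porcellus as the target (on this read-out lower numbers stand for an effect already at smaller amounts and higher numbers for an effect only at larger amounts of compound), compound 1 gives 5100 nM and compound 2 gives 700 nM. The change between them is methoxy in place of hydroxymethyl on a saturated chain carbon, two bonds along the chain from an aromatic nitrogen and it made a 7.3-fold lower number from compound 1 to compound 2 (0.86 log units; beyond the scatter), a modest step. In this assay compound 3 gives 22600 nM, the highest number among the three measured compounds. Compound 4 differs from compound 3 by methoxy in place of hydroxymethyl on a saturated chain carbon, two bonds along the chain from an aromatic nitrogen, which is the same change at the same place as that between compound 1 and compound 2; this change occurs twice among the compounds shown. Within the data shown here, because the same change gave a 7.3-fold lower number from compound 1 to compound 2 (0.86 log units; beyond the scatter) on the first core, a similar direction is expected on the second, though with only one earlier example the size is uncertain. The expected step in this assay is a 6.5-fold lower number from compound 3 to compound 4 (0.81 log units; beyond the scatter). Compound 4 is therefore estimated at 3500 nM, with a likely range from 1000 nM to 12000 nM.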

Compound 4, half-maximal effective concentration: 36100 nM
Beside the measured number, compound 4's estimate is 10-fold (1.01 log units) below it, and the stated range ends below it.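

On the core of compound 3, methoxy in place of hydroxymethyl gave a 1.6-fold higher number from compound 3 to compound 4 (0.20 log units; within the scatter) in this assay, so the two compounds cannot be told apart on this read-out. The step seen on the first core therefore did not carry over to the second, and the two steps differ by more than repeated measurements would account for: the same change on two cores in this assay, a 7.3-fold lower number (0.86 log units; beyond the scatter) from compound 1 to compound 2 and a 1.6-fold higher number (0.20 log units; within the scatter) from compound 3 to compound 4, 12-fold (1.07 log units) apart, beyond the scatter of two such steps

This shows that, in this series, the result of the change on one core cannot be assumed on the other, but with one pair per core it does not show why the cores differ or which part of them matters. The compounds shown leave open how an amine or a carboxylic acid in place of the methoxy would behave on either core, and whether a longer chain would separate the two cores in the same way. They also leave open whether a further core would follow compound 1 and compound 2 or compound 3 and compound 4.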